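The source may hold more compounds than are shown below. What is called first, only, known or untested is meant among the compounds shown, and "the series" means these compounds.

The compounds measured in an ADME assay on HepG2 cells (Homo sapiens) for cytotoxicity, read by CellTiter-Glo and ATP content, with a stated time of 72 h (a lower number here means that less compound is needed, a higher number that more compound is needed for the effect), so far:

compound 1 `CS(=O)(=O)c1ccc(C(=O)N2CCC(C(=O)N3CCc4ccccc4C3)CC2)cc1[N+](=O)[O-]` — > 27000 nM
compound 2 `CN(CC(=O)N1CCN(c2ccc(C(F)(F)F)cc2)CC1)C(=O)c1ccc(S(C)(=O)=O)c([N+](=O)[O-])c1` — 11900 nM

Compound 1 has in this assay not a number but a limit of the assay, > 27000 nM, and this is what the limit of > 27000 nM in this assay, at which 1 of the 2 values shown sits, describes. Compound 2 is the only one of the two with a numerical value, 11900 nM, in this assay. For the measured compounds named here, no pair of measured compounds differs in a single place, so no measured step is available for comparison.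

Compound 3 `CC1Cc2ccccc2N1C(=O)C1CCN(C(=O)c2ccc(S(C)(=O)=O)c([N+](=O)[O-])c2)CC1` has not yet been measured. Compared with compound 1, the two have the same atoms, joined differently: 2-methyl-2,3-dihydro-1H-indol-1-yl in place of 1,2,3,4-tetrahydroisoquinolin-2-yl on a carbonyl carbon. Going by the values given here, with compound 1 at a limit and no measured step to lean on, the expected step from compound 1 to compound 3 in this assay is a number no higher from compound 1 to compound 3 (the limit leaves the size open), which means no change beyond the usual scatter is anticipated. Compound 3 is therefore estimated at 27000 nM in this assay, in a range from 9000 nM to 81000 nM, with a fair chance that only a limit is reported again.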

Compound 3, half-maximal effective concentration: > 27000 nM
Compound 3 was reported as a limit (the forecaster's own chance of this, stated with the estimate: 55%); the middle value sits exactly at the limit.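

In this assay, compound 1 and compound 3 are both reported only as a limit, so no step between them can be read: the limit of > 27000 nM in this assay, at which 2 of the 3 values shown sit.

The compounds shown leave open whether 2-methyl-2,3-dihydro-1H-indol-1-yl in place of 1,2,3,4-tetrahydroisoquinolin-2-yl changes the read-out at all.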